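The source may hold more compounds than are shown below. What is called first, only, known or untested is meant among the compounds shown, and "the series" means these compounds.

Compound 1 `Cc1ccc2[nH]c(SCC(=O)N3CCC[C@H]3C(=O)Nc3ccccc3-n3cccc3)nc2c1`: 3 nM
Compound 2 `O=C(Nc1ccccc1-n1cccc1)[C@@H]1CCCN1C(=O)CSc1nc2ccccc2s1`: 39 nM

In an assay on CHO cells for displacement of a labelled ligand from Orexin/Hypocretin receptor type 1 (Homo sapiens) (a lower number here means a stronger inhibitor, a higher number a weaker inhibitor), compound 2 gives the highest of the two numbers; its nearest neighbour is compound 1, with a lower number, the gap being a 13-fold higher number from compound 1 to compound 2 (1.11 log units; beyond the scatter). Compound 3 `Cc1ccc2c(c1)nc(SCC(=O)N1CCC[C@H]1C(=O)Nc1ccccc1-n1cccc1)n2C` differs from compound 2 by 1,5-dimethyl-1H-benzimidazol-2-yl in place of 1,3-benzothiazol-2-yl on a sulfur. Among the compounds with values here, this change largely reverses the one step that bears on it, a 13-fold higher number from compound 1 to compound 2 (1.11 log units; beyond the scatter), a large step, though the methyl on the nitrogen is new and its effect is untested. Compound 3 is therefore expected to move toward compound 1, by a 4.9-fold lower number from compound 2 to compound 3 (0.69 log units; beyond the scatter) in this assay, with an estimate of 8 nM (range 2 nM to 30 nM).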

Compound 3, inhibition constant: 0.7 nM
Compound 3: the middle estimate sits 11-fold (1.06 log units) above what was measured; measured number outside the range, below it.
By their numbers in this assay, from the lowest: compound 3; then compound 1; then compound 2.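

In this assay the methyl on the aromatic nitrogen, untested until now, gives a 4.3-fold lower number from compound 1 to compound 3 (0.63 log units; beyond the scatter), so the hydrogen on that nitrogen is not needed for a low number at this position. The change on the sulfur also reaches further than the earlier step did, with a 56-fold lower number from compound 2 to compound 3 (1.75 log units; beyond the scatter), although both groups count no hydrogen-bond donors and the same two rings, so those counts do not separate them. Nothing available explains these differences. As far as these compounds go, whether an ethyl group or a longer chain on that nitrogen would hold this level remains open, as does what the 5-methyl group contributes once the nitrogen carries its methyl.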